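The source may report more compounds than this note shows. Statements on the series, on what has been measured and on what is new or still open speak of the compounds shown alone.

Measured so far:
compound 1, `Cc1ccc(-n2cnc3c(sc4ncc5sc(=S)[nH]c5c43)c2=O)cc1`: 1000 nM in an assay on membranes from cerebellum for displacement of a labelled ligand from metabotropic glutamate receptor 1 (Rattus norvegicus); on this read-out higher numbers stand for weaker inhibition and lower numbers for stronger inhibition
compound 2, `O=c1c2sc3ncc4cn[nH]c4c3c2ncn1-c1ccc(Cl)cc1`: 19.6 nM in this assay
compound 3, `O=c1c2sc3ncc4cc[nH]c4c3c2ncn1-c1ccc(Cl)cc1`: 2.4 nM in this assay

Compound 3 holds the lowest number of the three; compound 2 stands above it beyond the scatter, and compound 1 further still, also beyond the scatter. Compound 4, `Cc1ccc(-n2cnc3c(sc4ncc5cc[nH]c5c43)c2=O)cc1`, differs from compound 3 by methyl in place of chloro on an aromatic carbon. Among the measured compounds shown here, no measured pair on the shared core shows this exchange; compound 1 carries the same methylphenyl on a different core, so its number gives no direct guide. In this assay the step is expected to be small, toward a somewhat higher number, likely within the scatter. Compound 4 is expected at 5 nM, between 1.5 nM and 16 nM. This expectation corresponds to a step of a 2.1-fold higher number from compound 3 to compound 4 (0.32 log units; beyond the scatter).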

Compound 4, inhibition constant: 16.9 nM
The estimate for compound 4 lay 3.4-fold (0.53 log units) below the measured number; the whole stated range lies below it.
By their numbers in this assay, from the lowest: compound 3; then compounds 4 and 2 (each within the scatter of the next); then compound 1.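

Among the compounds shown here, on the shared core, the exchange of 4-chlorophenyl for 4-methylphenyl gives the first comparison that differs in one place. In this assay it gives a 7.0-fold higher number from compound 3 to compound 4 (0.85 log units; beyond the scatter) and so lies beyond the scatter. This place, para to a large group, therefore responds to a change of a single heavy atom, and the chloro compound holds the lower number. Nothing at hand accounts for this step.

As far as these compounds go, whether fluoro, methoxy, an amine or a longer chain at this place would give a number nearer to compound 3 or compound 4 stays open. Also open, from the compounds shown here alone, is whether the same exchange gives a step of this size on another core.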